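Shifting a fluorine on the alkyne-linked pyridine

This account rests on a few compounds, and the source may have more. Where it says the series, first, only, none or still open, it means among the compounds named here.

Compound 1, `C[C@@H](NC(=O)c1ccc(C#Cc2ccccc2)cn1)C(C)(C)O`, gives 43.2% in an ADME assay on HEK293 cells for agonist activity at metabotropic glutamate receptor 5 (Rattus norvegicus), read by fluorescence and calcium flux; on this read-out higher numbers stand for larger maximal responses and lower numbers for smaller maximal responses.
Compound 2, `Cc1cccc(C#Cc2ccc(C(=O)N[C@H](C)C(C)(C)O)nc2)c1`, gives 20.8% in this assay.
Compound 3, `C[C@@H](NC(=O)c1ccc(C#Cc2ccc(F)cn2)cn1)C(C)(C)O`, gives 13.5% in this assay.

Compound 3 sits at the low end of these three numbers: it lies beyond the scatter from compound 1 but only within the scatter of compound 2. The steps that lead to it are a number 29.7 percentage points lower from compound 1 to compound 3 (beyond the scatter) and a number 7.3 percentage points lower from compound 2 to compound 3 (within the scatter), while a number 22.4 percentage points lower from compound 1 to compound 2 (beyond the scatter) shows that a methyl on an aromatic carbon of the phenyl already lowers the response.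

Compound 4, `C[C@@H](NC(=O)c1ccc(C#Cc2ncccc2F)cn1)C(C)(C)O`, differs from compound 3 as follows: 3-fluoropyridin-2-yl in place of 5-fluoropyridin-2-yl on a triple-bonded carbon. Within the data shown here, no measured pair shows a fluorine moving from one position of the pyridine to another, so no step bears directly on this change; the measured changes at the triple-bonded carbon all went downward or stayed within the scatter, and compound 3 already leaves little room below it. In this assay no step beyond the scatter is therefore expected, with a number 1.5 percentage points higher from compound 3 to compound 4 (within the scatter) as the anticipated change. Compound 4 is estimated at 15%, within a range from 4% to 34%.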

Compound 4, largest response reached (reported as efficacy), in percent of the reference or control that the assay uses: 29.2%
The estimate for compound 4 lay 14.2 percentage points below the measured number; the measured number falls inside the stated range.
By their numbers in this assay, from the lowest: compounds 3, 2 and 4 (each within the scatter of the next, the first and the last beyond it); then compound 1.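

In this assay the place of the fluorine on the pyridine matters in its own right: the two groups have the same atoms, joined differently, yet the exchange of 5-fluoropyridin-2-yl for 3-fluoropyridin-2-yl gives a number 15.7 percentage points higher from compound 3 to compound 4 (beyond the scatter) and so the low number of compound 3 cannot be taken as a feature of every fluoropyridine on the triple-bonded carbon. The 3-fluoropyridin-2-yl group still does not match the phenyl of compound 1, with a number 14 percentage points lower from compound 1 to compound 4 (beyond the scatter) on that side, and against the 3-methylphenyl of compound 2 the change is a number 8.4 percentage points higher from compound 2 to compound 4 (within the scatter) and gives these two compounds no order. Nothing measured here accounts for the effect of moving the fluorine on the maximal response.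

The compounds shown leave open what a chlorine, a methoxy group or a nitrile would do in place of the fluorine of the 3-fluoropyridin-2-yl group. They also leave open whether the gap between the two fluoropyridines would hold if the amide side chain of the shared core gave way to a longer chain or an amine.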